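A few compounds are considered here, and "the series" means these few. Any claim that something is new, unique, unknown or untested is made for them only; others in the source may bear on it.

Measured in a physicochemical assay for solubility, in phosphate buffer, measured as kinetic solubility; on this read-out lower numbers stand for lower solubility and higher numbers for higher solubility:
- compound 1 `CC(C)[C@@H](c1ccc(-c2ccc3cccc(F)c3c2)[nH]c1=O)[C@@H]1OC(=O)NC1=O` gives 27400 nM
- compound 2 `CC(C)C(c1ccc(-c2ccc3cccc(F)c3c2)[nH]c1=O)C1NC(=O)NC1=O` gives 10600 nM
- compound 3 `C/C(=C1/OC(=O)NC1=O)C(c1ccc(-c2ccc3cccc(F)c3c2)[nH]c1=O)C(C)C` gives 17200 nM

Compound 1 lies within the scatter of compound 3 and beyond the scatter above compound 2.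

Compound 4 `CC(C)[C@H](C[C@H]1SC(=O)NC1=O)c1ccc(-c2ccc3cccc(F)c3c2)[nH]c1=O` keeps the core of compound 1 and carries one change ((2,4-dioxo-1,3-thiazolidin-5-yl)methyl in place of 2,4-dioxo-1,3-oxazolidin-5-yl on a saturated chain carbon bound to an aromatic carbon and a saturated chain carbon). Here (2,4-dioxo-1,3-thiazolidin-5-yl)methyl stands in place of 2,4-dioxo-1,3-oxazolidin-5-yl, on a saturated chain carbon bound to an aromatic carbon and a saturated chain carbon.

Within the data shown here, the only measured step at this place is a 1.6-fold higher number from compound 2 to compound 3 (0.21 log units; within the scatter) (within the scatter). Among the measured compounds shown here, no measured compound carries the (2,4-dioxo-1,3-thiazolidin-5-yl)methyl group, so that step is only a loose guide to the size of the change.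

Other groups at this place give compound 2 (10600 nM) and compound 3 (17200 nM), and these values pull the expectation from compound 1 towards lower numbers. In this assay a small downward step is therefore expected, close to the edge of the scatter, and the uncertainty is wide. The estimated step is a 1.8-fold lower number from compound 1 to compound 4 (0.26 log units; within the scatter) (an expectation only). Compound 4 is estimated at 15000 nM (expected range 6000 nM to 32000 nM).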

Compound 4, solubility: 31200 nM
Compound 4: middle estimate off by 2.1-fold (0.32 log units), on the low side, and the stated range covers the measured number.
By their numbers in this assay, from the lowest: compounds 2, 3, 1 and 4 (each within the scatter of the next, the first and the last beyond it).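

In this assay, the place on a saturated chain carbon bound to an aromatic carbon and a saturated chain carbon accepts (2,4-dioxo-1,3-thiazolidin-5-yl)methyl in place of 2,4-dioxo-1,3-oxazolidin-5-yl, with a 1.1-fold higher number from compound 1 to compound 4 (0.06 log units; within the scatter) as the step, so the two numbers cannot be told apart. The earlier step, a 1.6-fold higher number from compound 2 to compound 3 (0.21 log units; within the scatter), involved no sulfur-containing group. The new pair shows that a sulfur-containing group can replace 2,4-dioxo-1,3-oxazolidin-5-yl without a difference beyond the scatter, with the hydrogen-bond donor and acceptor counts the same on both sides. No measurement at hand accounts for this result.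

The entering group alters the ring hetero atom and the attachment together, and the compounds shown do not separate the two: that would take 2,4-dioxo-1,3-thiazolidin-5-yl without the methyl link, or 2,4-dioxo-1,3-oxazolidin-5-yl with it. Also open, going by these compounds, is whether a group of another kind at this place, such as a carboxylic acid or a primary amine, would stay within the scatter of compound 1 or move beyond it.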